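Series notes: aryl variation at the fused-core aromatic carbon

A few compounds are considered here, and "the series" means these few. Any claim that something is new, unique, unknown or untested is made for them only; others in the source may bear on it.

Measured compounds:
- Compound 1, `CCCS(=O)(=O)Nc1ccc(F)c(C(=O)c2n[nH]c3ncc(-c4cccc(O)c4)cc23)c1F`; in an assay for binding affinity to dual specificity mitogen-activated protein kinase kinase 4 (Homo sapiens), read by KINOMEscan, tested at 100 nM (a lower number here means a stronger effect, a higher number a weaker effect of the compound at the concentration tested), compound 1 gives 2.2%.
- Compound 2, `CCCS(=O)(=O)Nc1ccc(F)c(C(=O)c2n[nH]c3ncc(-c4ccc(O)cc4)cc23)c1F`; in this assay compound 2 gives 0.75%.
- Compound 3, `CCCS(=O)(=O)Nc1ccc(F)c(C(=O)c2n[nH]c3ncc(-c4cccc(N(C)C)c4)cc23)c1F`; in this assay compound 3 gives 26%.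

Compound 3 stands highest of the three numbers; its nearest neighbour is compound 1, a number 23.8 percentage points higher from compound 1 to compound 3 (beyond the scatter), and its furthest is compound 2, a number 25.3 percentage points higher from compound 2 to compound 3 (beyond the scatter), both beyond the scatter. Compounds 1 and 2 differ only within the scatter, a number 1.5 percentage points lower from compound 1 to compound 2 (within the scatter).

Compound 4, `CCCS(=O)(=O)Nc1ccc(F)c(C(=O)c2n[nH]c3ncc(-c4ccc(C(C)(C)C)cc4)cc23)c1F`, is not yet measured. The change from compound 3 is 4-(tert-butyl)phenyl in place of 3-(dimethylamino)phenyl on an aromatic carbon. The two steps that bear on it are those into compound 3: exchanging a hydroxy for a dimethylamino moved the number up by a modest amount in both cases. Compound 4 carries neither a hydroxy nor a dimethylamino, so the steps only show the direction of loss when the hydroxy goes; nothing measured here tells how a tert-butyl compares with a dimethylamino. The expectation is therefore a number in this assay at or somewhat above that of compound 3, with wide uncertainty. For compound 4 the estimated value is 45%, expected between 15% and 85%. This estimate implies a step of a number 19 percentage points higher from compound 3 to compound 4 (beyond the scatter), expected to lie near or just beyond the scatter.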

Compound 4, a percentage reported as activity, at one concentration (the size of the read-out at that concentration, not a potency): 46%
Beside the measured number, compound 4's estimate is 1 percentage points below it; the range from low to high includes it.
By their numbers in this assay, from the lowest: compounds 2 and 1 (each within the scatter of the next); then compound 3; then compound 4.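

In this assay, among the compounds shown here, the all-carbon 4-(tert-butyl)phenyl group gives the highest number so far, with a rise a number 20 percentage points higher from compound 3 to compound 4 (beyond the scatter) that adds to the loss already seen with the dimethylamino group. The cleanest comparison is the exchange of hydroxy for tert-butyl on the 4-substituted phenyl, a number 45.3 percentage points higher from compound 2 to compound 4 (beyond the scatter), which shows that a 4-substituent alone does not keep the number low and that the identity of the group matters. The step of a number 43.8 percentage points higher from compound 1 to compound 4 (beyond the scatter) is of similar size but changes both the group and where it sits on the phenyl, as does the step from the dimethylamino compound, so neither separates the two changes.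

The data shown give no explanation for these steps. Still open, going by these compounds, are how an unsubstituted phenyl, a 4-(dimethylamino)phenyl and a 3-(tert-butyl)phenyl would compare, which would separate the group from its place on the ring, and whether a primary amine or a carboxylic acid in place of the hydroxy would keep the number as low as in the hydroxyphenyl compounds.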